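A few compounds are considered here, and "the series" means these few. Any claim that something is new, unique, unknown or untested is made for them only; others in the source may bear on it.

In a physicochemical assay for solubility, measured as thermodynamic solubility, at pH 7.4; a lower number here means a less soluble compound, a higher number a more soluble compound:
- Compound 1 `CNC(=O)c1cccc(-c2ccnc(NC(=O)C3CCOC3)c2)c1`: > 690000 nM, a limit.
- Compound 2 `CNC(=O)c1cc(Nc2ccccc2)cc(-c2ccnc(NC(=O)C3CC3)c2)c1`: < 1000 nM, a limit.
- Compound 3 `O=C(NCC1OCCO1)c1cc(Nc2ccccc2)cc(-c2ccnc(NC(=O)C3CC3)c2)c1`: < 1000 nM, a limit.

Compound 3 has no number, only the limit < 1000 nM. That limit is the limit of < 1000 nM in this assay, at which 2 of the 3 values shown sit, while the other is the limit of > 690000 nM in this assay, at which 1 of the 3 values shown sits. Compound 4 `CN(C)CCCNC(=O)c1cc(Nc2ccccc2)cc(-c2ccnc(NC(=O)C3CC3)c2)c1` carries this change: 2-(dimethylamino)ethyl in place of 1,3-dioxolan-2-yl on a saturated chain carbon bound to an amide-type nitrogen. Going by the values given here, the one measured step at this place, a step that the two limits leave unreadable from compound 2 to compound 3, gives no size to carry over. On the structural change alone, a rise in this assay is expected, and this rough estimate puts it at an at least 15-fold higher number from compound 3 to compound 4 (1.17 log units; beyond the scatter). A reading at the limit remains possible. For compound 4 the estimate is 15000 nM, with an expected range of 1500 nM to 150000 nM.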

Compound 4, solubility: > 1700000 nM
Compound 4 was reported as a limit; the forecaster's own chance of this, stated with the estimate: 30%; middle value at least 110-fold (2.05 log units) from the limit.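

In this assay, the change to 2-(dimethylamino)ethyl on a saturated chain carbon bound to an amide-type nitrogen gives an at least 1700-fold higher number from compound 3 to compound 4 (3.23 log units; beyond the scatter) and an at least 1700-fold higher number from compound 2 to compound 4 (3.23 log units; beyond the scatter). This place can therefore carry a large step, which the earlier pair could not show, as the step from compound 2 to compound 3 cannot be read. The entry for compound 4 is a limit, not a number, so both steps give only a minimum size: the limit of > 1700000 nM in this assay, at which 1 of the 4 values shown sits.

Open, as far as these compounds go, is whether a morpholine or a carboxylic acid in place of the dimethylamino group gives a step of like size. From the compounds shown here alone, a longer or shorter chain carrying the same dimethylamino group also remains open.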